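Ethyl Ester Versus Free Acid: A Second Test

The source may hold more compounds than are shown below. What is called first, only, known or untested is meant among the compounds shown, and "the series" means these compounds.

In an assay on isolated protein with retinoic acid receptor gamma (Homo sapiens) as the target, read by TR-FRET, with a stated time of 4 h (a lower number here means that less compound is needed, a higher number that more compound is needed for the effect), compound 2 `Cc1sc(-c2ccc(C(=O)O)cc2)nc1-c1ccc2c(c1)C(C)(C)CCC2(C)C` gives 98.9 nM, while compound 1 `CCOC(=O)c1ccc(-c2nc(-c3ccc4c(c3)C(C)(C)CCC4(C)C)c(C)s2)cc1` gives 847 nM. The difference between them is ethyl in place of hydrogen on an oxygen next to a carbonyl group, and it produced the step of an 8.6-fold higher number from compound 2 to compound 1 (0.93 log units; beyond the scatter).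

Compound 3 `Cc1sc(-c2ccc(C(=O)O)cc2)nc1-c1ccccc1` rests on a different core; how its core differs from that of compound 2 is not broken down here. In this assay compound 3 gives 109 nM, a number within the scatter of the value of compound 2, so the two acids cannot be told apart on this read-out.

Compound 4 `CCOC(=O)c1ccc(-c2nc(-c3ccccc3)c(C)s2)cc1` is still to be measured. It differs from compound 3 by ethyl in place of hydrogen on an oxygen next to a carbonyl group, the same change, at the same place, that turns compound 2 into compound 1. The step from compound 3 to compound 4 is therefore expected to be about as large as the earlier one, namely an 8.3-fold higher number from compound 3 to compound 4 (0.92 log units; beyond the scatter), because the same change gave an 8.6-fold higher number from compound 2 to compound 1 (0.93 log units; beyond the scatter) and the two acids give values within the scatter of each other. On that basis compound 4 is estimated to give 900 nM in this assay, most likely between 350 nM and 2500 nM.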

Compound 4, half-maximal effective concentration: 383 nM
For compound 4 the middle estimate is 2.3-fold (0.37 log units) above the measured one, and the stated range covers the measured number.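

On the second core, the change from carboxy to ethoxycarbonyl again raises the number in this assay, giving a 3.5-fold higher number from compound 3 to compound 4 (0.55 log units; beyond the scatter). For the compounds shown here, the direction is the same on both cores, and the two step sizes cannot be told apart, so in this small set the change carries over from one core to the other in direction and, as far as the scatter allows, in size: the same change on two cores in this assay, an 8.6-fold higher number (0.93 log units; beyond the scatter) from compound 2 to compound 1 and a 3.5-fold higher number (0.55 log units; beyond the scatter) from compound 3 to compound 4, 2.4-fold (0.39 log units) apart, within the scatter of two such steps This rests on only two matched pairs in a single assay, so it does not show that the change would behave alike on any further core, and it gives no explanation for the higher numbers of the two ethyl esters.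

The compounds shown leave open whether a methyl ester, a longer chain on the same oxygen, or an amide in place of the ester would give a step of similar size. They also leave open how the change would behave on a core carrying a further group, such as an amine or a halogen.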